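Ester variation in aminothiophene kinase series

The compounds below may be only part of what the source reports. "The series", "measured", "known", "first", "only" and "open" are said of these compounds alone.

Measured compounds in an assay on isolated protein for inhibition of protein kinase C zeta type (Homo sapiens), with stated times of 1 h and 2.5 min, tested at 30 uM; a higher number here means more inhibition at the concentration tested (going by the name of the read-out), a lower number less inhibition:
- compound 1 `CCOC(=O)c1c(-c2ccc(OC)c(OC)c2)csc1N` gives 100%
- compound 2 `COc1ccc(-c2csc(N)c2C(=O)OCc2ccccc2)cc1OC` gives 100%
- compound 3 `COc1ccc(-c2csc(N)c2C(=O)OCc2ccc(C)cc2)cc1OC` gives 50%

Compound 3 stands lowest of the three numbers in this assay. Its nearest neighbour is compound 1, with the step of a number 50 percentage points lower from compound 1 to compound 3 (beyond the scatter), and compound 2 lies equally far, with the step of a number 50 percentage points lower from compound 2 to compound 3 (beyond the scatter). The step of no change at the digits printed from compound 1 to compound 2 (within the scatter) shows that the number stays level when phenyl replaces methyl on the saturated chain carbon bound to an oxygen next to a carbonyl group, while the step of a number 50 percentage points lower from compound 2 to compound 3 (beyond the scatter) shows the number lower when methyl replaces hydrogen on an aromatic carbon.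

Compound 4 `COc1ccc(-c2csc(N)c2C(=O)OCc2ccccc2F)cc1OC` is not yet measured. The change from compound 3 is 2-fluorophenyl in place of 4-methylphenyl on a saturated chain carbon bound to an oxygen next to a carbonyl group. Among the measured compounds shown here, the only measured step that bears on it is a number 50 percentage points lower from compound 2 to compound 3 (beyond the scatter), since the 4-methylphenyl of compound 3 leaves; nothing among the measured compounds speaks to a fluorine on that ring. On these data alone, the expectation is therefore a recovery toward the level of compound 2, read as a step of a number 30 percentage points higher from compound 3 to compound 4 (beyond the scatter) in this assay, with some uncertainty because the fluorine itself is untested. Compound 4 is estimated at 80% in this assay, within a range of 50% to 100%.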

Compound 4, a percentage reported as inhibition, at one concentration (the size of the read-out at that concentration, not a potency): 100%
Compound 4: the middle estimate sits 20 percentage points below what was measured, and the stated range covers the measured number.
By their numbers in this assay, from the lowest: compound 3; then compounds 1, 2 and 4 (each within the scatter of the next).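

At the saturated chain carbon bound to an oxygen next to a carbonyl group, the low number for 4-methylphenyl in this assay does not extend to every substituted phenyl ring: 2-fluorophenyl in place of 4-methylphenyl gives a number 50 percentage points higher from compound 3 to compound 4 (beyond the scatter) on this read-out, and fluoro in place of hydrogen on the aromatic carbon gives no change at the digits printed from compound 2 to compound 4 (within the scatter) in the same assay. Against the small alkyl group, the change to 2-fluorophenyl gives no change at the digits printed from compound 1 to compound 4 (within the scatter) as well, so among the four compounds only compound 3 stands apart at this place. Nothing on hand accounts for the difference between the 4-methylphenyl and 2-fluorophenyl results.

The 4-methylphenyl and 2-fluorophenyl groups differ in both the substituent and where it sits, so 4-fluorophenyl and 2-methylphenyl would be needed to tell whether the lower number in this assay follows the methyl or its ring position. On these data alone, with compound 1, compound 2 and compound 4 matching at a single tested concentration, any difference in potency among them also stays open.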